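The source may report more compounds than this note shows. Statements on the series, on what has been measured and on what is new or still open speak of the compounds shown alone.

Measured compounds in an assay on isolated protein for antagonist activity at Voltage-dependent L-type calcium channel subunit alpha-1C (Cavia porcellus), with a stated time of 15 min; on this read-out lower numbers stand for stronger inhibition and higher numbers for weaker inhibition:
compound 1 `CCOC(=O)C1=C(C)NC(C)=C(C(=O)OC)C1c1csc(-c2ccc(Cl)cc2)n1` gives 22000 nM
compound 2 `COC(=O)C1=C(C)NC(C)=C(C(=O)OCc2ccccc2)C1c1csc(-c2ccc(Cl)cc2)n1` gives 64900 nM

Compound 2 stands highest of these two numbers; compound 1 sits a clear step lower. Compound 3 `COC(=O)C1=C(C)NC(C)=C(C(=O)OC(C)c2ccccc2)C1c1csc(-c2ccc(Cl)cc2)n1` differs from compound 2 by methyl in place of hydrogen on a saturated chain carbon bound to an aromatic carbon and an oxygen next to a carbonyl group. Going by the values given here, the only measured step touching this ester group is a 3.0-fold higher number from compound 1 to compound 2 (0.47 log units; beyond the scatter), a modest rise for a larger group there. Among the compounds with values here, no measured pair adds a methyl at this carbon, so the direction rests on that single step alone. Expected is therefore a 1.3-fold higher number from compound 2 to compound 3 (0.12 log units; within the scatter), a small rise or none beyond the scatter. Compound 3 is estimated at 85000 nM, with a range from 30000 nM to 250000 nM.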

Compound 3, half-maximal inhibitory concentration: 7620 nM
The estimate for compound 3 lay 11-fold (1.05 log units) above the measured number; measured number below the stated range.
By their numbers in this assay, from the lowest: compound 3; then compound 1; then compound 2.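

In this assay, benzyl to 1-phenylethyl gives an 8.5-fold lower number from compound 2 to compound 3 (0.93 log units; beyond the scatter), which runs opposite to a 3.0-fold higher number from compound 1 to compound 2 (0.47 log units; beyond the scatter), so larger groups at this ester do not simply raise the number. Phenyl in place of hydrogen on the ethyl chain gives a 2.9-fold lower number from compound 1 to compound 3 (0.46 log units; beyond the scatter), so phenyl at this ester goes with a lower number when the added methyl is present. No evidence here accounts for this reversal.

Still open, from the compounds shown here alone, is whether a longer chain at this carbon, such as ethyl in place of the added methyl, lowers the number further. Also open, going by these compounds, is how an amine on the ester chain would read.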